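The source may hold more compounds than are shown below. What is called first, only, known or untested is meant among the compounds shown, and "the series" means these compounds.

Compound 1 `COc1ccc(NC(=O)c2nc(-c3cc(OC)c(OC)c(OC)c3)n(-c3ccc(OC)cc3)n2)cc1` gives 67% in a functional assay on the whole organism for inhibition, with Rattus norvegicus as the target, read by paw edema, with stated times of 30 min and 3 h, at a dose of 0.28 mmol/kg by the oral route; a higher number here means more inhibition at the dose given (going by the name of the read-out), a lower number less inhibition. Compound 2 `COc1ccc(-n2nc(C(=O)Nc3ccccc3OC)nc2-c2cc(OC)c(OC)c(OC)c2)cc1` gives 30%. Compound 3 `COc1ccc(-n2nc(C(=O)Nc3ccc(C)cc3)nc2-c2cc(OC)c(OC)c(OC)c2)cc1` gives 60%.

Compound 3 stands second of the three numbers: the difference to compound 1, a number 7 percentage points lower from compound 1 to compound 3 (within the scatter), lies within the scatter, while the difference to compound 2, a number 30 percentage points higher from compound 2 to compound 3 (beyond the scatter), lies beyond it. Compound 4 `COc1ccc(-n2nc(C(=O)Nc3ccc(O)cc3)nc2-c2cc(OC)c(OC)c(OC)c2)cc1` differs from compound 3 by hydroxy in place of methyl on an aromatic carbon. The step that bears on it most is the exchange of the group on the same aromatic carbon, a number 7 percentage points lower from compound 1 to compound 3 (within the scatter), which stayed within the scatter; the other two steps moved the group to another position and are less informative. The step of a number 2 percentage points lower from compound 3 to compound 4 (within the scatter) is therefore expected to stay small, and compound 4 is expected to give about 58%, within 40% to 75%.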

Compound 4, a percentage reported as inhibition, in the whole organism at one dose (the size of the read-out at that dose, not a potency): 50%
Compound 4: the middle estimate sits 8 percentage points above what was measured, within the range that was stated.
By their numbers in this assay, from the lowest: compound 2; then compounds 4, 3 and 1 (each within the scatter of the next, the first and the last beyond it).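

Hydroxy on this aromatic carbon brings a hydrogen-bond donor that methyl lacks, yet the change stays small: a number 10 percentage points lower from compound 3 to compound 4 (within the scatter). Set against methoxy on the same carbon, hydroxy shows a clearer drop, a number 17 percentage points lower from compound 1 to compound 4 (beyond the scatter), although methyl lies within the scatter of both. The 4-hydroxyphenyl group still holds an advantage over 2-methoxyphenyl, with a number 20 percentage points higher from compound 2 to compound 4 (beyond the scatter). Nothing given here explains these differences. Going by these compounds, whether an amine or a carboxylic acid on this carbon would keep the inhibition remains open.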